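Anilide variation on the shared core: mouse microsomal clearance

The source may report more compounds than this note shows. Statements on the series, on what has been measured and on what is new or still open speak of the compounds shown alone.

Measured compounds:
compound 1 `CN1C[C@H](C(=O)Nc2ccc(C#N)cc2)[C@@H](c2ccc(/C=C/C(=O)Nc3ccccc3N)cc2)C1` — 35 mL/min/kg
compound 2 `CC(C)c1ccc(NC(=O)[C@H]2CN(C)C[C@@H]2c2ccc(/C=C/C(=O)Nc3ccccc3N)cc2)cc1` — 54 mL/min/kg
compound 3 `COc1cccc(NC(=O)[C@H]2CN(C)C[C@@H]2c2ccc(/C=C/C(=O)Nc3ccccc3N)cc2)c1` — 65 mL/min/kg

In an in vitro ADME assay on microsomes from liver (Mus musculus) for pharmacokinetics, read by LC-MS, with a stated time of 10 min, tested at 1 uM (on this read-out lower numbers stand for slow clearance and higher numbers for fast clearance), compound 1 stands at the lowest of the three numbers. Its steps to the others, a 1.5-fold higher number from compound 1 to compound 2 (0.19 log units; within the scatter) and a 1.9-fold higher number from compound 1 to compound 3 (0.27 log units; within the scatter), are both within the scatter, as is a 1.2-fold higher number from compound 2 to compound 3 (0.08 log units; within the scatter), so the three anilides on the shared core are not separated by this assay.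

Compound 4 `CN1C[C@H](C(=O)Nc2ccc(Cl)cc2F)[C@@H](c2ccc(/C=C/C(=O)Nc3ccccc3N)cc2)C1` has not yet been measured. It differs from compound 1 in one place: 4-chloro-2-fluorophenyl in place of 4-cyanophenyl on an amide-type nitrogen.

For the measured compounds named here, the steps that bear on this change are those that also swap the aryl group on the amide-type nitrogen of compound 1, namely a 1.5-fold higher number from compound 1 to compound 2 (0.19 log units; within the scatter) and a 1.9-fold higher number from compound 1 to compound 3 (0.27 log units; within the scatter). Going by the values given here, neither moved this assay beyond the scatter, and nothing among the measured compounds marks a halogenated aryl group as different in kind. For compound 4 no step beyond the scatter is therefore expected in this assay, with a slight lean to a higher number in line with the two measured anilide swaps. Compound 4 is estimated at 45 mL/min/kg, range 25 mL/min/kg to 80 mL/min/kg, which is expected to mean a 1.3-fold higher number from compound 1 to compound 4 (0.11 log units; within the scatter).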

Compound 4, clearance: 43 mL/min/kg
Compound 4: middle estimate off by 1.0-fold (0.02 log units), on the high side, within the range that was stated.
By their numbers in this assay, from the lowest: compounds 1, 4, 2 and 3 (each within the scatter of the next).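

In this assay, for the compounds shown here, the swap to 4-chloro-2-fluorophenyl on the amide-type nitrogen gives a result that stays within the scatter (a 1.2-fold higher number from compound 1 to compound 4 (0.09 log units; within the scatter)), so the first halogenated aryl group at this position does not stand apart from the 4-cyanophenyl anilide. It also stands within the scatter of the other two anilides (a 1.5-fold lower number from compound 3 to compound 4 (0.18 log units; within the scatter); a 1.3-fold lower number from compound 2 to compound 4 (0.10 log units; within the scatter)), so none of the four aryl groups on this nitrogen is separated from the rest. No accompanying measurement offers an account of these numbers.

Open, as far as these compounds go, is whether an aryl group carrying a primary amine or a carboxylic acid, or a longer alkyl chain in place of the aryl group, would give a step beyond the scatter in this assay. Changes elsewhere on the shared core also remain open.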